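The compounds below may be only part of what the source reports. "The series", "measured", "known", "first", "only" and "open" are said of these compounds alone.

Measured compounds:
Compound 1 `Oc1ccccc1-c1cc(-c2ccccc2)cc(-c2ccccc2O)n1`: > 50000 nM, a limit of the assay and not a number
Compound 2 `Oc1cccc(-c2cc(-c3ccccc3)cc(-c3ccccc3)n2)c1`: 9950 nM
Compound 3 `Oc1cccc(-c2cc(-c3ccccc3)cc(-c3cccs3)n2)c1`: 10900 nM

These values come from a functional assay on HCT-15 cells (Homo sapiens) for cytotoxicity, read by ELISA, with a stated time of 2 days; a higher number here means a weaker inhibitor, a lower number a stronger inhibitor. There, compound 3 gives 10900 nM, level with compound 2 once the usual scatter is allowed for. The next compound, compound 4 `Oc1cccc(-c2cc(-c3ccccc3)cc(-c3ccsc3)n2)c1`, has the same atoms as compound 3, joined differently: thiophen-3-yl in place of thiophen-2-yl on an aromatic carbon. For the measured compounds named here, only one measured step bears on this change. It put thiophen-2-yl in place of phenyl at the same carbon and gave a 1.1-fold higher number from compound 2 to compound 3 (0.04 log units; within the scatter). A swap of a whole ring changed nothing measurable there, so no shift beyond the scatter is expected in this assay for this smaller move. The expected change is a 1.0-fold lower number from compound 3 to compound 4 (0.02 log units; within the scatter). For compound 4 the estimated value is 10500 nM, with an expected range of 5500 nM to 20000 nM.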

Compound 4, half-maximal inhibitory concentration: 7660 nM
Estimate against measurement, compound 4: 1.4-fold (0.14 log units) above; the range from low to high includes it.
By their numbers in this assay, from the lowest: compounds 4, 2 and 3 (each within the scatter of the next). At a limit, above all of these: compound 1.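

Moving the point of attachment on the thiophene, from thiophen-2-yl to thiophen-3-yl, gives a 1.4-fold lower number from compound 3 to compound 4 (0.15 log units; within the scatter) in this assay. Set against phenyl, thiophen-3-yl gives a 1.3-fold lower number from compound 2 to compound 4 (0.11 log units; within the scatter), so phenyl and both thiophene attachments stand level at this carbon next to the ring nitrogen. Nothing shown here accounts for this sameness.

From the compounds shown here alone, whether an amine, a carboxylic acid or a longer chain at this carbon would shift the number beyond the scatter remains open.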